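The compounds below may be only part of what the source reports. "The series", "measured", "known", "first", "only" and "open" are said of these compounds alone.

Compound 1 (`COc1ccc(CNC(=O)/C(C#N)=C/c2ccc[nH]2)cc1`) and compound 2 (`N#C/C(=C\c1ccc[nH]1)C(=O)NCc1ccc(Cl)c(Cl)c1`) are two cores that carry the same 1H-pyrrol-2-yl group; how the two cores differ is not broken down here. In a functional assay on HT-29 cells (Homo sapiens) for inhibition, read by MTT assay, with a stated time of 72 h (a lower number here means a stronger inhibitor of growth, a higher number a weaker inhibitor of growth), compound 1 gives only a limit, > 50000 nM. In this assay compound 2 gives 85000 nM, the highest number among the measured compounds. Compound 3 (`COc1ccc(CNC(=O)/C(C#N)=C/c2ccco2)cc1`) is compound 1 with one change, (furan-2-yl in place of 1H-pyrrol-2-yl on a double-bonded chain carbon bound to a double-bonded chain carbon). In this assay compound 3 gives 22000 nM, which makes an at least 2.2-fold lower number from compound 1 to compound 3 (0.35 log units; beyond the scatter). Since compound 1 gives only a limit, the size of that step is known only as its smallest possible value, because of the limit of > 50000 nM in this assay, at which 1 of the 3 values shown sits. Compound 4 (`N#C/C(=C\c1ccco1)C(=O)NCc1ccc(Cl)c(Cl)c1`) has not yet been measured, and it applies the same change to compound 2: furan-2-yl in place of 1H-pyrrol-2-yl on a double-bonded chain carbon bound to a double-bonded chain carbon. If the change acts on the core of compound 2 as it did in the measured pair, the number for compound 4 is expected to drop by about a 2.4-fold lower number from compound 2 to compound 4 (0.39 log units; beyond the scatter), resting on an at least 2.2-fold lower number from compound 1 to compound 3 (0.35 log units; beyond the scatter). Compound 4 is therefore estimated at 35000 nM, with a likely range from 12000 nM to 100000 nM.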

Compound 4, concentration for 50% growth inhibition: 20000 nM
For compound 4 the middle estimate is 1.8-fold (0.24 log units) above the measured one, within the range that was stated.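

In this assay, putting furan-2-yl in place of 1H-pyrrol-2-yl on the core of compound 2 gives a 4.3-fold lower number from compound 2 to compound 4 (0.63 log units; beyond the scatter). The same change also lowers the number on the core of compound 1, so its direction carries over between the two cores shown: the same change on two cores in this assay, an at least 2.2-fold lower number (0.35 log units; beyond the scatter) from compound 1 to compound 3 and a 4.3-fold lower number (0.63 log units; beyond the scatter) from compound 2 to compound 4; the limit leaves it open whether they differ What this does not show is whether the size of the step carries over as well, because compound 1 stands at a limit and not at a number: the limit of > 50000 nM in this assay, at which 1 of the 4 values shown sits.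

Only two cores are shown, so it remains open whether the same direction would hold on any other core in this series. As far as these compounds go, it is also open how the number would move with an amine or a carboxylic acid in place of the furan-2-yl group, on a double-bonded chain carbon bound to a double-bonded chain carbon.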